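The source may report more compounds than this note shows. Statements on the series, on what has been measured and on what is new or still open speak of the compounds shown alone.

Working notes on the series. Compound 1 `Nc1cc(N)c2nc(-c3ccccc3)c(Oc3ccc(Cl)c(Cl)c3)nc2c1` gives 38000 nM in a functional assay on HOP-62 cells (Homo sapiens) for inhibition, read by sulforhodamine B assay, with a stated time of 48 h; a lower number here means a stronger inhibitor of growth, a higher number a weaker inhibitor of growth. Compound 2 `CCOC(=O)[C@H](CCC(=O)O)NC(=O)c1ccc(Sc2nc3cc(N)cc(N)c3nc2-c2ccccc2)cc1` gives 85100 nM in the same assay, a higher number beyond the scatter, so compound 1 stands as the lower of the two numbers. Compound 3 `Nc1cc(N)c2nc(-c3ccccc3)c(Sc3ccc(F)cc3)nc2c1` is not yet measured; it differs from compound 1 in one place: (4-fluorophenyl)sulfanyl in place of 3,4-dichlorophenoxy on an aromatic carbon. Nothing measured tracks this change directly. The step from compound 1 to compound 3 is expected to be small, a 1.3-fold higher number from compound 1 to compound 3 (0.12 log units; within the scatter), with no clear direction beyond the scatter. Compound 3 is thus estimated at 50000 nM, within 15000 nM to 150000 nM.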

Compound 3, concentration for total growth inhibition: 34700 nM
Compound 3: the middle estimate sits 1.4-fold (0.16 log units) above what was measured, within the range that was stated.
By their numbers in this assay, from the lowest: compounds 3 and 1 (each within the scatter of the next); then compound 2.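

In this assay, among the compounds shown here, (4-fluorophenyl)sulfanyl in place of 3,4-dichlorophenoxy on this aromatic carbon gives a 1.1-fold lower number from compound 1 to compound 3 (0.04 log units; within the scatter), the first direct reading at this position. The two groups differ at once in the linking atom and in the halogens on the ring, so this single step cannot separate the two differences. No evidence on the origin of this result is available. Still open, as far as these compounds go, is how the 4-fluorophenyl ring would read with an oxygen link in place of the sulfur. Equally open, from the compounds shown here alone, is whether a morpholine or a plain methoxy group at this position would give a number beyond the scatter.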